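A few compounds are considered here, and "the series" means these few. Any claim that something is new, unique, unknown or untested is made for them only; others in the source may bear on it.

Three members of the series have been run in a functional assay on IMR-32 cells (Homo sapiens) for cytotoxicity, read by sulforhodamine B assay, with a stated time of 48 h; a lower number here means a stronger inhibitor, a higher number a weaker inhibitor: compound 1 `C=CCOc1ccc(F)cc1C(=O)c1cccnc1`, compound 2 `C=CCOc1cc(Br)ccc1C(=O)c1cccnc1` and compound 3 `C=CCOc1ccc(Br)cc1C(=O)c1cccnc1`. Compound 1 gives 91000 nM, compound 2 gives 98000 nM and compound 3 gives 88000 nM. Compound 2 carries the highest of the three numbers, but its gaps to compound 1 and to compound 3 both fall within the scatter, so no order among the three can be read from these values. Among the compounds with values here, the one step between compounds that differ in a single place, a 1.0-fold lower number from compound 1 to compound 3 (0.01 log units; within the scatter), is likewise flat.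

Compound 4 `O=C(c1cccnc1)c1ccc(Br)cc1O` is the next member. It differs from compound 2 in one place: hydrogen in place of allyl on an oxygen on an aromatic ring. Within the data shown here, no measured step touches this oxygen; the only step in hand, a 1.0-fold lower number from compound 1 to compound 3 (0.01 log units; within the scatter), concerns bromo in place of fluoro on an aromatic carbon and gives no information on the allyloxy group. The three measured values sit within the scatter of one another, so the expectation for compound 4 rests on the level of compound 2 rather than on any trend. Without directional evidence, the step is estimated as a 1.0-fold lower number from compound 2 to compound 4 (0.01 log units; within the scatter), inside the usual scatter. Compound 4 is therefore expected to give 95000 nM in this assay, with a range from 35000 nM to 260000 nM.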

Compound 4, half-maximal inhibitory concentration: 89000 nM
Estimate against measurement, compound 4: 1.1-fold (0.03 log units) above, and the stated range covers the measured number.
By their numbers in this assay, from the lowest: compounds 3, 4, 1 and 2 (each within the scatter of the next).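

In this assay, the change from allyloxy to hydroxy gives a 1.1-fold lower number from compound 2 to compound 4 (0.04 log units; within the scatter), so the first variation at this oxygen leaves the number within the scatter, even though the allyl removed carries 3 heavy atoms and a double bond outside aromatic rings. The earlier compounds shown here gave information only on a halogen exchange on an aromatic carbon; this pair adds that, on the core of compound 2, the allyl group is not required for the level seen in this assay, and a free hydroxy is compatible with that same level. No measurement in hand bears on the reason for this flat result.

As far as these compounds go, what remains open is whether any group on this oxygen can move the number beyond the scatter, for example a longer alkyl chain, a chain ending in an amine, or a carboxylic acid. From the compounds shown here alone, it is also open whether the flat allyloxy to hydroxy step holds on other members, such as compound 1 with its fluoro group, since this single pair speaks only for the bromo compound 2.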